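This account rests on a few compounds, and the source may have more. Where it says the series, first, only, none or still open, it means among the compounds named here.

In a functional assay on PC-3 cells (Homo sapiens) for cytotoxicity, read by MTT assay, with a stated time of 48 h (on this read-out lower numbers stand for stronger inhibition and higher numbers for weaker inhibition), compound 1 `O=C(O)CN1C(=O)/C(=C/c2nc3ccccc3n2Cc2ccc([N+](=O)[O-])cc2)SC1=S` gives 8270 nM and compound 2 `O=C(O)CN1C(=O)/C(=C/c2nc3ccccc3n2Cc2ccc(F)cc2)SC1=S` gives 4860 nM. Among the measured compounds shown here, these are the only two numbers available so far, and they do not separate: compound 2 stands level with its sole neighbour, within the scatter. The next structure, compound 3 `Cc1ccc(Cn2c(/C=C3\SC(=S)N(CC(=O)O)C3=O)nc3ccccc32)cc1`, keeps the same core and turns 4-fluorobenzyl into 4-methylbenzyl, with methyl in place of fluoro on an aromatic carbon, para to a large group: methyl in place of fluoro on an aromatic carbon. For the measured compounds named here, only one measured step bears on this change, the exchange of nitro for fluoro at that same place, and it was small: a 1.7-fold lower number from compound 1 to compound 2 (0.23 log units; within the scatter). Going by the values given here, no measured compound carries methyl there, so this single step is a thin guide, and it gives no ground for expecting a clear direction. No step beyond the scatter is therefore expected in this assay. The expected step is a 1.1-fold higher number from compound 2 to compound 3 (0.05 log units; within the scatter). Compound 3 is estimated at 5500 nM, with an expected range from 2400 nM to 12000 nM.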

Compound 3, half-maximal inhibitory concentration: 2640 nM
Compound 3: the middle estimate sits 2.1-fold (0.32 log units) above what was measured, within the range that was stated.
By their numbers in this assay, from the lowest: compounds 3, 2 and 1 (each within the scatter of the next, the first and the last beyond it).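

Among the compounds shown here, at the aromatic carbon para to a large group, in this assay the change from nitro to methyl gives a 3.1-fold lower number from compound 1 to compound 3 (0.50 log units; beyond the scatter) and is the first step at this position to lie beyond the scatter, so the group held here can matter to the number, if only modestly. Methyl in place of fluoro, by contrast, gives a 1.8-fold lower number from compound 2 to compound 3 (0.27 log units; within the scatter) and stays within the scatter, so these two groups cannot be told apart here, just as fluoro and nitro could not be; only nitro and methyl, the two ends of this short series, separate. No evidence is given on why the numbers of these compounds differ.

With only nitro, fluoro and methyl shown at this position, it remains open whether a chlorine, a methoxy group, an amine or a longer chain such as ethyl would carry the number further in either direction. As far as these compounds go, it also remains open whether the modest gain seen with methyl would hold if the carboxylic acid on the shared core were replaced by an amide.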